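The source may hold more compounds than are shown below. What is called first, only, known or untested is meant among the compounds shown, and "the series" means these compounds.

Measured so far:
- compound 1 `C=C1C(=O)[C@@]23C(=O)OC[C@]4(C(=O)CCC(C)(C)[C@H]4C=O)[C@@H]2CC[C@@H]1[C@H]3OC(=O)c1ccc(C)cc1`: 2240 nM
- compound 2 `C=C1C(=O)[C@@]23C(=O)OC[C@]4(C(=O)CCC(C)(C)[C@H]4C=O)[C@@H]2CC[C@@H]1[C@H]3OC(=O)c1ccc(C(F)(F)F)cc1`: 4930 nM

For the measured compounds named here, in a functional assay on MGC-803 cells (Homo sapiens) for cytotoxicity, read by MTT assay, with a stated time of 72 h (a lower number here means a stronger inhibitor, a higher number a weaker inhibitor), compound 1 gives 2240 nM, the lower of the two numbers so far, which makes it the stronger inhibitor of the pair. Going by the values given here, its only neighbour, compound 2, gives 4930 nM.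

Compound 3 `C=C1C(=O)[C@@]23C(=O)OC[C@]4(C(=O)CCC(C)(C)[C@H]4C=O)[C@@H]2CC[C@@H]1[C@H]3OC(=O)c1ccc(F)cc1` keeps the core of compound 1 and alters a single group: fluoro in place of methyl on an aromatic carbon. Put simply, 4-methylphenyl becomes 4-fluorophenyl, with fluoro in place of methyl on an aromatic carbon.

Among the compounds with values here, only one measured step bears on this change: a 2.2-fold higher number from compound 1 to compound 2 (0.34 log units; beyond the scatter). That step, trifluoromethyl in place of methyl on an aromatic carbon, is modest but beyond the scatter. It is a single comparison with a different incoming group, so it is a weak guide and shows no general pattern. It points to a small move towards a higher number, perhaps one that stays within the scatter.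

The expected change is a 1.3-fold higher number from compound 1 to compound 3 (0.13 log units; within the scatter), and this estimate is uncertain. For compound 3 the estimated value is 3000 nM, with an expected range from 1500 nM to 6000 nM.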

Compound 3, half-maximal inhibitory concentration: 3960 nM
Estimate against measurement, compound 3: 1.3-fold (0.12 log units) below; measured number inside the range.
By their numbers in this assay, from the lowest: compounds 1, 3 and 2 (each within the scatter of the next, the first and the last beyond it).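

In this assay, putting fluoro in place of methyl on this aromatic carbon gives a 1.8-fold higher number from compound 1 to compound 3 (0.25 log units; within the scatter) and putting fluoro in place of trifluoromethyl gives a 1.2-fold lower number from compound 2 to compound 3 (0.10 log units; within the scatter) so compound 3 cannot be told apart from either of the other two compounds. For the compounds shown here, the only clear separation at this position remains the modest one between the methyl and trifluoromethyl compounds, a 2.2-fold higher number from compound 1 to compound 2 (0.34 log units; beyond the scatter) and with fluoro now filling the gap between them, the three groups form a narrow, continuous band of numbers rather than distinct levels, which is more than the single earlier comparison could show. No measurement available here explains why the three numbers fall so close together.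

All three groups are small and sit on the same carbon of the same ring, so the compounds shown do not reveal whether this position would still give numbers in this band with a group of a different kind, such as an amine, a hydroxyl or a carboxylic acid. A longer chain, such as butyl, or a second ring attached at this carbon also remains an open case.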